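The source may hold more compounds than are shown below. What is called first, only, known or untested is meant among the compounds shown, and "the series" means these compounds.

Four compounds of one series are compared in a functional assay on HeLa cells (Homo sapiens) for inhibition, read by MTT assay, with a stated time of 48 h; a higher number here means a weaker inhibitor of growth, a lower number a stronger inhibitor of growth. Compound 1 `Cn1cc(C2CC(c3ccc(Cl)cc3)=NN2C(=O)c2cccnc2)c2cc(Br)ccc21` gives 5200 nM in this assay. Compound 2 `Cn1cc(C2CC(c3ccc(Br)cc3)=NN2C(=O)c2cccnc2)c2cc(Br)ccc21` differs from it in one place; in this assay compound 2 returns only a limit, > 10000 nM. The change made there is bromo in place of chloro on an aromatic carbon and it produces an at least 1.9-fold higher number from compound 1 to compound 2 (0.28 log units; that floor lies within the scatter). That step rests on the limit at which one of the three values sits (the limit of > 10000 nM in this assay, at which 1 of the 3 values shown sits), so its true size is not fixed, only its floor. Compound 3 `COc1ccc2c(c1)c(C1CC(c3ccc(Cl)cc3)=NN1C(=O)c1ccc(OC)nc1)cn2C` carries a different core; how that core differs from the core of compound 1 is not broken down here. In this assay compound 3 gives 2260 nM, the lowest of the two numbers, with compound 1 as the nearest neighbour at a higher number beyond the scatter. Compound 4 `COc1ccc2c(c1)c(C1CC(c3ccc(Br)cc3)=NN1C(=O)c1ccc(OC)nc1)cn2C` has not been measured. It stands to compound 3 as compound 2 stands to compound 1: the change is bromo in place of chloro on an aromatic carbon, the same change at a place described in the same words. Beside the measured step, the step expected in this assay from compound 3 to compound 4 is a 2.2-fold higher number from compound 3 to compound 4 (0.34 log units; beyond the scatter), an estimate resting on the measured step of an at least 1.9-fold higher number from compound 1 to compound 2 (0.28 log units; that floor lies within the scatter) and on the value of compound 3, 2260 nM. Compound 4 is therefore expected in this assay at about 5000 nM, within a range from 2500 nM to 12000 nM, with a real chance that only a limit is returned.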

Compound 4, concentration for 50% growth inhibition: > 10000 nM
Compound 4: no number, only a limit (the forecaster's own chance of this, stated with the estimate: 25%); at least 2.0-fold (0.30 log units) between middle value and limit.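

In this assay compound 4 returns only a limit, > 10000 nM. Bromo in place of chloro on the core of compound 3 gives an at least 4.4-fold higher number from compound 3 to compound 4 (0.64 log units; beyond the scatter), so on this core even the floor of the step lies beyond the scatter, and the change runs in the same direction on both cores, though the floor on the core of compound 1 stays within the scatter: the same change on two cores in this assay, an at least 1.9-fold higher number (0.28 log units; that floor lies within the scatter) from compound 1 to compound 2 and an at least 4.4-fold higher number (0.64 log units; beyond the scatter) from compound 3 to compound 4; the limit leaves it open whether they differ. The change therefore carries across these two cores in direction only, and neither the true size of either step nor any effect of the core on that size can be read, as some of the values are limits: the limit of > 10000 nM in this assay, at which 2 of the 4 values shown sit.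

Open is how an amine, a carboxylic acid or a fluoro group would read in this assay at the same place on the aromatic ring, since only chloro and bromo appear there in the compounds shown. Also open, on these data alone, is whether a longer chain in place of the methoxy groups of compound 3 and compound 4 would change the picture on that core.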